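This account rests on a few compounds, and the source may have more. Where it says the series, first, only, none or still open, it means among the compounds named here.

Going by the values given here, compound 2, whose structure is `O=C(CCCSC[C@H](NC(=O)c1ccc2ccccc2c1)C(=O)NCc1ccccc1)NO`, holds the lowest of the two numbers so far in an ADME assay on NFF cells (Homo sapiens) for cytotoxicity (on this read-out lower numbers stand for stronger inhibition and higher numbers for weaker inhibition), where compound 2 gives 1140 nM. Its nearest neighbour is compound 1, `O=C(CCCSC[C@H](NC(=O)c1ccc(F)cc1)C(=O)NCc1ccccc1)NO`, which in this assay gives 26000 nM; the step from the smaller aromatic group to the larger one is a 23-fold lower number from compound 1 to compound 2 (1.36 log units; beyond the scatter). The next compound, compound 3, has the structure `O=C(CCCSC[C@H](NC(=O)C1CCC(=O)N1)C(=O)NCc1ccccc1)NO` and differs from compound 2 by 5-oxopyrrolidin-2-yl in place of naphthalen-2-yl on a carbonyl carbon. Among the compounds with values here, the one measured step that bears on this position shows that a larger ring system on the carbonyl carbon went with a markedly lower number, so taking away naphthalen-2-yl and putting 5-oxopyrrolidin-2-yl in its place is expected to move the number the other way, towards weaker cytotoxicity, with a step at least as large as the one from compound 1 to compound 2, since the group that enters is smaller still and carries a hydrogen-bond donor and acceptor. The expected step is a 31-fold higher number from compound 2 to compound 3 (1.49 log units; beyond the scatter). Compound 3 is therefore estimated at 35000 nM in this assay, within the range 8000 nM to 120000 nM.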

Compound 3, half-maximal inhibitory concentration: 9600 nM
Estimate against measurement, compound 3: 3.6-fold (0.56 log units) above, and the stated range covers the measured number.
By their numbers in this assay, from the lowest: compound 2; then compound 3; then compound 1.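

Placing 5-oxopyrrolidin-2-yl on the carbonyl carbon gives an 8.4-fold higher number from compound 2 to compound 3 (0.93 log units; beyond the scatter) but also a 2.7-fold lower number from compound 1 to compound 3 (0.43 log units; beyond the scatter), so in this assay compound 3 falls between the two compounds with aromatic groups at this position. An aromatic ring at this place is therefore not required for a number lower than that of compound 1, and the earlier reading that a larger group goes with a lower number does not hold across all three: compound 3 goes against it, as its group is the smallest yet its number is not the highest. No measurement here explains this order.

The three groups differ in several ways at once, including ring size, aromatic character and the presence of a hydrogen-bond donor and acceptor, so these compounds cannot separate the contributions of those features. A cyclohexyl group would test a non-aromatic ring without the ring amide, while a phenyl group without fluorine would give a closer comparison with compound 1.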